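This account rests on a few compounds, and the source may have more. Where it says the series, first, only, none or still open, it means among the compounds named here.

Series notes, an assay on isolated protein for inhibition of Rho-associated protein kinase 1 (Homo sapiens), tested at 30 uM; a higher number here means more inhibition at the concentration tested (going by the name of the read-out), a lower number less inhibition:

compound 1, `Cn1cnc2c(Nc3ccccc3)ncnc21`: 0%
compound 2, `Cn1cnc2c(Nc3ccc(F)cc3)ncnc21`: 7%
compound 3, `c1ccc(Sc2ncnc3[nH]cnc23)cc1`: 33%

Going by the values given here, the one matched pair so far is compound 1 to compound 2, where the change is fluoro in place of hydrogen on an aromatic carbon. It gives a number 7 percentage points higher from compound 1 to compound 2 (within the scatter), so the fluoro adds nothing that can be told apart from noise on that core. Compound 3 has the highest number of the three; the difference between its core and the core of compound 1 is not broken down here, and the two values simply show compound 3 well above compound 1 and compound 2.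

Compound 4, `Fc1ccc(Sc2ncnc3[nH]cnc23)cc1`, has not been measured. It carries the same change relative to compound 3, namely (fluoro in place of hydrogen on an aromatic carbon), at a place described in the same words as for compound 1 to compound 2. The expected step of a number 4 percentage points higher from compound 3 to compound 4 (within the scatter) is therefore small, resting on a number 7 percentage points higher from compound 1 to compound 2 (within the scatter), which lies within the scatter. Going by these compounds, whether the core of compound 3 responds differently to the fluoro is unknown, so the range is kept wide. For compound 4 the estimated value is 37%, between 22% and 52%.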

Compound 4, a percentage reported as inhibition, at one concentration (the size of the read-out at that concentration, not a potency): 37%
Compound 4: middle estimate and measured number agree at the digits printed; measured number inside the range.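

In this assay, fluoro in place of hydrogen on an aromatic carbon gives a number 4 percentage points higher from compound 3 to compound 4 (within the scatter), and the step agrees with the one seen on the other core: the same change on two cores in this assay, a number 7 percentage points higher (within the scatter) from compound 1 to compound 2 and a number 4 percentage points higher (within the scatter) from compound 3 to compound 4, 3 percentage points apart, within the scatter of two such steps. The change therefore carries between the core of compound 1 and the core of compound 3 without a step that can be told from noise on either. Going by these compounds alone, this does not show that fluoro has no effect elsewhere: only two cores and this one substitution are covered, and a read-out at a single concentration is not a potency.

Still open, going by these compounds, is whether a different group in place of that hydrogen, such as a methoxy, an amine or a carboxylic acid, would give a step beyond the scatter on either core. Also open, on these data alone, is which part of the core of compound 3 separates it from compound 1 and compound 2, as these compounds differ in more than one place.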